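A Carbamate Replaces the Dienyl Chain on the Shared Core

The source may hold more compounds than are shown below. What is called first, only, known or untested is meant among the compounds shown, and "the series" means these compounds.

Compound 2 `CC(C)=CCC/C(C)=C/COc1cc(=O)n(CCCO)c2c1CC(CC=C(C)C)C(C)(C)C2` is the lowest of the three measured compounds: in a functional assay on PANC-1 cells (Homo sapiens) for inhibition, read by MTT assay, with a stated time of 24 h, tested at 10 uM (on this read-out lower numbers stand for less inhibition and higher numbers for more inhibition at the one concentration tested (going by the name of the read-out)), compound 2 gives 10.6%. Compound 1 `CC(C)=CCOc1cc(=O)n(CCCO)c2c1CC(CC=C(C)C)C(C)(C)C2` gives 20.7% in this assay, and compound 3 `COc1ccc(OCCCOc2cc(=O)n(CCCO)c3c2CC(CC=C(C)C)C(C)(C)C3)cc1` gives 47.7%. The step of a number 10.1 percentage points lower from compound 1 to compound 2 (beyond the scatter) accompanied 3-methylbut-2-en-1-yl in place of hydrogen on a saturated chain carbon bound to a double-bonded chain carbon, whereas a number 27 percentage points higher from compound 1 to compound 3 (beyond the scatter) and a number 37.1 percentage points higher from compound 2 to compound 3 (beyond the scatter) both accompanied the arrival of a 2-(4-methoxyphenoxy)ethyl group on the saturated chain carbon bound to an oxygen on the aromatic ring.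

Compound 4 `COc1ccc(NC(=O)Oc2cc(=O)n(CCCO)c3c2CC(CC=C(C)C)C(C)(C)C3)cc1` differs from compound 2 in one place: (4-methoxyphenyl)carbamoyl in place of 3,7-dimethylocta-2,6-dien-1-yl on an oxygen on an aromatic ring. The step from compound 2 to compound 3 bears most directly on this change, since it also removed the 3,7-dimethylocta-2,6-dien-1-yl chain and brought in a group containing a methoxyphenyl ring, and it was large. The step from compound 1 to compound 3, bringing in the same methoxyphenyl-bearing group, was modest but pointed the same way. Compound 4 is therefore expected to show a rise in this assay of about a number 31.4 percentage points higher from compound 2 to compound 4 (beyond the scatter). Compound 4 is estimated at 42%, within a range of 22% to 62%.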

Compound 4, a percentage reported as inhibition, at one concentration (the size of the read-out at that concentration, not a potency): 3.7%
Compound 4: middle estimate off by 38.3 percentage points, on the high side, and the stated range ends above it.
By their numbers in this assay, from the lowest: compounds 4 and 2 (each within the scatter of the next); then compound 1; then compound 3.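

On an oxygen on an aromatic ring of the shared core, the (4-methoxyphenyl)carbamoyl group did not repeat the rise seen with the methoxyphenyl-bearing chain of compound 3: in this assay, replacing 3,7-dimethylocta-2,6-dien-1-yl gave a number 6.9 percentage points lower from compound 2 to compound 4 (within the scatter), so compound 4 cannot be told apart from compound 2, while replacing 3-methylbut-2-en-1-yl gave a number 17 percentage points lower from compound 1 to compound 4 (beyond the scatter). A methoxyphenyl ring in the group on this oxygen therefore does not by itself go with a high number, as compound 3 gives 47.7% and compound 4 gives 3.7%, so the link that carries the ring matters at least as much as the ring in this small set. No measurement available here explains the difference between these two linked groups.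

The compounds shown leave open whether any carbamoyl on this oxygen can reach the level of compound 3, or whether this result is particular to the 4-methoxyphenyl group. An amine or a carboxylic acid in place of the methoxy group, or a longer chain between the carbamoyl nitrogen and the ring, would test that question.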